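The source may hold more compounds than are shown below. What is called first, only, known or untested is meant among the compounds shown, and "the series" means these compounds.

Series notes. Compound 2 `Fc1cccc(-c2nc(Nc3ccc(Cl)cc3)c3cc(F)ccc3n2)c1` carries a 4-chlorophenyl on a nitrogen on an aromatic ring of the shared core. In a functional assay on MCF7 cells (Homo sapiens) for cytotoxicity, read by MTT assay, with a stated time of 48 h (on this read-out higher numbers stand for weaker inhibition and lower numbers for stronger inhibition), compound 2 gives only a limit, > 50000 nM. Compound 1 `COc1ccccc1Nc1nc(-c2cccc(F)c2)nc2ccc(F)cc12` likewise reaches only a limit in this assay, > 50000 nM. Compound 3 `Fc1cccc(-c2nc(Nc3ccccc3Br)c3cc(F)ccc3n2)c1` also stops at a limit there, > 50000 nM. Hence (the limit of > 50000 nM in this assay, at which 3 of the 3 values shown sit), and the steps a step that the two limits leave unreadable from compound 1 to compound 2 and a step that the two limits leave unreadable from compound 2 to compound 3 cannot be sized; the same holds for a step that the two limits leave unreadable from compound 1 to compound 3. Compound 4 `Nc1cccc(Nc2nc(-c3cccc(F)c3)nc3ccc(F)cc23)c1` differs from compound 2 by 3-aminophenyl in place of 4-chlorophenyl on a nitrogen on an aromatic ring. Within the data shown here, since none of the measured steps has a readable size, no direction beyond the scatter can be claimed for the step to compound 4. Compound 4 is expected to show no clearer inhibition, estimated at 60000 nM (range 20000 nM to 200000 nM), which means an expected step that the limit leaves unreadable from compound 2 to compound 4.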

Compound 4, half-maximal inhibitory concentration: > 50000 nM
Compound 4: only a limit was reported (the forecaster's own chance of this, stated with the estimate: 75%); the middle value is on the limit's open side.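

In this assay, among these compounds, compound 4 also stops at a limit, > 50000 nM and no step from compound 1, compound 2 or compound 3 to compound 4 can be read: the limit of > 50000 nM in this assay, at which 4 of the 4 values shown sit. From the compounds shown here alone, whether any group on that nitrogen reaches a measurable value in this assay stays open.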